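Tetrazolyl pyridine amides: acetamido on the phenyl ring

The source may report more compounds than this note shows. Statements on the series, on what has been measured and on what is new or still open speak of the compounds shown alone.

Measured so far in a functional assay on the whole organism with Rattus norvegicus as the target, at a dose of 1 mg/kg by the oral route; on this read-out lower numbers stand for a weaker effect and higher numbers for a stronger effect at the one dose given:
compound 1 `O=C(Nc1nn[nH]n1)c1cc(Cl)cc(-c2ccccc2)n1`: 40%
compound 2 `CCCc1ccc(-c2cc(Cl)cc(C(=O)Nc3nn[nH]n3)n2)cc1`: 78%
compound 3 `COc1cc(C(=O)Nc2nn[nH]n2)nc(-c2ccccc2)c1`: 62%

Compound 3 stands second highest of the three numbers; compound 2 lies above it and compound 1 below it, both gaps beyond the scatter. Compound 4 `COc1cc(C(=O)Nc2nn[nH]n2)nc(-c2ccc(NC(C)=O)cc2)c1` differs from compound 3 by acetamido in place of hydrogen on an aromatic carbon. The change sits on the same phenyl ring that carries propyl in place of hydrogen in compound 2, and that step, a number 38 percentage points higher from compound 1 to compound 2 (beyond the scatter), was large. The step of a number 22 percentage points higher from compound 1 to compound 3 (beyond the scatter), methoxy in place of chloro on the other ring, was modest and does not bear directly on substitution of the phenyl ring. For the measured compounds named here, no compound with acetamido has been measured, so the expectation rests on the step to compound 2 alone and is held back: acetamido is a different group from propyl. An increase for compound 4 is expected, a number 10 percentage points higher from compound 3 to compound 4 (within the scatter), smaller than the propyl step and with a wide range. Compound 4 is estimated at 72%, between 48% and 90%.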

Compound 4, a percentage reported as inhibition, in the whole organism at one dose (the size of the read-out at that dose, not a potency): 0%
Compound 4: the middle estimate sits 72 percentage points above what was measured; the measured number lies below the stated range.
By their numbers in this assay, from the lowest: compound 4; then compound 1; then compound 3; then compound 2.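

In this assay, substitution on the phenyl ring does not act in one direction: acetamido in place of hydrogen, para to a large group, gives a number 62 percentage points lower from compound 3 to compound 4 (beyond the scatter), whereas propyl in place of hydrogen on that ring gave a number 38 percentage points higher from compound 1 to compound 2 (beyond the scatter). The two steps start from different cores, methoxy in compound 3 and chloro in compound 1. They also differ in the entering group, and these compounds cannot separate the two differences. No available data bear on the reason for the fall with acetamido.

Open, on these data alone, is whether an amine, a carboxylic acid or a chain longer than propyl at this place keeps the effect or loses it. Also open, as far as these compounds go, is whether acetamido on the core of compound 1 brings the same fall, and whether propyl on the core of compound 3 brings a rise.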